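The compounds below may be only part of what the source reports. "The series", "measured", "known", "first", "only" and "open" are said of these compounds alone.

Working notes on the series. Within the data shown here, in a functional assay on MDA-MB-468 cells (Homo sapiens) for antiproliferative activity, read by CellTiter-Glo, with a stated time of 96 h (on this read-out lower numbers stand for stronger inhibition and higher numbers for weaker inhibition), compound 1 `COc1ccc(-c2nsc3c2NC(=O)CC3c2cccc(F)c2)cc1` gives 1410 nM and compound 2 `COc1ccc(-c2nsc3c2NC(=O)CC3c2ccc(F)cc2)cc1` gives 1850 nM as the only two numbers so far. Compound 2 has one neighbour, compound 1, and the two values lie within the scatter of each other.

Compound 3 `COc1ccc(-c2nsc3c2NC(=O)CC3c2ccsc2)cc1` differs from compound 2 in one place (thiophen-3-yl in place of 4-fluorophenyl on a saturated ring carbon), with thiophen-3-yl in place of 4-fluorophenyl on a saturated ring carbon. Among the measured compounds shown here, the one measured step at this carbon (a 1.3-fold higher number from compound 1 to compound 2 (0.12 log units; within the scatter)) is small, but it only exchanges 3-fluorophenyl for 4-fluorophenyl. For the measured compounds named here, no measured compound carries a five-membered aromatic ring there, so the data give only weak guidance for this change.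

No step beyond the scatter is expected in this assay and neither direction is favoured. The estimated move (a 1.2-fold lower number from compound 2 to compound 3 (0.09 log units; within the scatter)) is accordingly small, with a wide margin for the untested ring. Compound 3 is expected at 1500 nM within an estimated range of 600 nM to 3800 nM on this evidence.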

Compound 3, half-maximal inhibitory concentration: 163 nM
Compound 3: middle estimate off by 9.2-fold (0.96 log units), on the high side; the measured number lies below the stated range.
By their numbers in this assay, from the lowest: compound 3; then compounds 1 and 2 (each within the scatter of the next).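

The saturated ring carbon, three ring bonds from the ring nitrogen, responds strongly to the kind of aromatic ring it carries: in this assay, thiophen-3-yl in place of 4-fluorophenyl gives an 11-fold lower number from compound 2 to compound 3 (1.05 log units; beyond the scatter), and thiophen-3-yl in place of 3-fluorophenyl gives an 8.7-fold lower number from compound 1 to compound 3 (0.94 log units; beyond the scatter). The earlier step, a 1.3-fold higher number from compound 1 to compound 2 (0.12 log units; within the scatter), only moved the fluorine within the six-membered aromatic ring and stayed within the scatter, so it gave no sign that this position could discriminate between substituents; compound 3 now stands clearly apart from both fluorophenyl compounds. Nothing at hand accounts for the difference between the thiophen-3-yl and fluorophenyl groups.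

With thiophen-3-yl as the only five-membered aromatic ring shown, the compounds leave open whether the lower number goes with the ring sulfur, the attachment through the ring's 3-position or the five-membered ring in general. Thiophen-2-yl, furan-3-yl and unsubstituted phenyl at the same carbon would help separate these readings, while a cyclopentyl ring would test whether an aromatic ring is needed there at all.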